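Aryl swaps on the ring nitrogen, cytotoxicity series

The source may report more compounds than this note shows. Statements on the series, on what has been measured and on what is new or still open speak of the compounds shown alone.

Measured in a functional assay on NCI-H322 cells (Homo sapiens) for cytotoxicity, read by MTT assay, with a stated time of 24 h; a lower number here means a stronger inhibitor, a higher number a weaker inhibitor:

Compound 1, `COc1ccc(/C=C\C(=O)O)c(OCc2cn(-c3ccc(C#N)cc3)nn2)c1CC=C(C)C`: 18600 nM
Compound 2, `COc1ccc(/C=C\C(=O)O)c(OCc2cn(-c3nc4ccccc4s3)nn2)c1CC=C(C)C`: 23000 nM

Compound 2 holds the highest of the two numbers in this assay; the nearest is compound 1, and the step of a 1.2-fold higher number from compound 1 to compound 2 (0.09 log units; within the scatter) is within the scatter, so the two cannot be ordered.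

Going by the values given here, compound 3, `COc1ccc(/C=C\C(=O)O)c(OCc2cn(-c3cccc([N+](=O)[O-])c3)nn2)c1CC=C(C)C`, differs from compound 2 at the same position as the one change measured so far: 3-nitrophenyl in place of 1,3-benzothiazol-2-yl on an aromatic nitrogen. Among the compounds with values here, the only step that bears on it is a 1.2-fold higher number from compound 1 to compound 2 (0.09 log units; within the scatter), which exchanged one aryl group for another on that ring nitrogen and produced nothing beyond the scatter. Within the data shown here, with a single step of that kind as the only guide, the series gives no ground to expect that a third aryl group at this position moves the number beyond the scatter in either direction.

Compound 3 is therefore expected near 21000 nM, with a range of 9000 nM to 50000 nM. The expected step is a 1.1-fold lower number from compound 2 to compound 3 (0.04 log units; within the scatter), that is, no change beyond the scatter.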

Compound 3, half-maximal inhibitory concentration: 43200 nM
Compound 3: middle estimate off by 2.1-fold (0.31 log units), on the low side, within the range that was stated.
By their numbers in this assay, from the lowest: compounds 1, 2 and 3 (each within the scatter of the next, the first and the last beyond it).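

In this assay, the aryl group on the ring nitrogen now gives its first step beyond the scatter: a 2.3-fold higher number from compound 1 to compound 3 (0.37 log units; beyond the scatter), with 3-nitrophenyl in place of 4-cyanophenyl, though the step is modest. The other new step, a 1.9-fold higher number from compound 2 to compound 3 (0.27 log units; within the scatter), stays within the scatter, so 3-nitrophenyl and 1,3-benzothiazol-2-yl cannot be ordered. Going by these compounds alone, compound 2 thus lies within the scatter of both compound 1 and compound 3, and only the pair at the two ends of the series separates, so this position tolerates these aryl swaps with small shifts at most. Nothing available bears on the reason for the separation between those two compounds.

Since 4-cyanophenyl and 3-nitrophenyl differ in both the substituent and its place on the ring, the compounds shown cannot tell which of the two accounts for the step. Also open, as far as these compounds go, is how the number responds to an amine or a carboxylic acid on that aryl ring, or to a plain alkyl chain in place of the aryl group on the ring nitrogen.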